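Halogen variation on the amide aryl group

The source may hold more compounds than are shown below. What is called first, only, known or untested is meant among the compounds shown, and "the series" means these compounds.

Compound 1, `O=C(CSc1nc(Nc2ccccc2)c2ccccc2n1)Nc1ccc(F)cc1`, gives 9560 nM in a functional assay on PC-3 cells (Homo sapiens) for inhibition, read by MTT assay, with a stated time of 72 h; on this read-out lower numbers stand for stronger inhibition and higher numbers for weaker inhibition.
Compound 2, `O=C(CSc1nc(Nc2ccccc2)c2ccccc2n1)Nc1ccc(Br)cc1`, gives 8450 nM in this assay.

Compound 2 and compound 1 sit within the scatter of each other, as the step of a 1.1-fold lower number from compound 1 to compound 2 (0.05 log units; within the scatter) shows. Compound 3, `O=C(CSc1nc(Nc2ccccc2)c2ccccc2n1)Nc1ccc(Cl)c(Cl)c1`, differs from compound 2 by 3,4-dichlorophenyl in place of 4-bromophenyl on an amide-type nitrogen. For the measured compounds named here, the one measured step, a 1.1-fold lower number from compound 1 to compound 2 (0.05 log units; within the scatter), exchanged one halogen for another and moved nothing beyond the scatter; no measured step adds a second halogen. Compound 3 is therefore expected to land near compound 2, with a 1.2-fold lower number from compound 2 to compound 3 (0.08 log units; within the scatter) inside the scatter. Compound 3 is estimated at 7000 nM in this assay, between 2500 nM and 20000 nM.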

Compound 3, half-maximal inhibitory concentration: 12100 nM
Estimate against measurement, compound 3: 1.7-fold (0.24 log units) below; the range from low to high includes it.
By their numbers in this assay, from the lowest: compounds 2, 1 and 3 (each within the scatter of the next).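

Going from one halogen to two on the amide aryl group moves nothing beyond the scatter, with a 1.4-fold higher number from compound 2 to compound 3 (0.16 log units; within the scatter) and a 1.3-fold higher number from compound 1 to compound 3 (0.10 log units; within the scatter) (this assay). On the amide-type nitrogen, 4-fluorophenyl, 4-bromophenyl and 3,4-dichlorophenyl therefore cannot be told apart in this read-out. No available evidence bears on this result. The compounds shown leave open whether an amine, a carboxylic acid or a methoxy group on this phenyl ring would give a step beyond the scatter. They also leave open what a longer chain in place of the phenyl ring would do.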